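Replacing the Amide Arm on a Shared Core

A few compounds are considered here, and "the series" means these few. Any claim that something is new, unique, unknown or untested is made for them only; others in the source may bear on it.

Compound 1, `Cc1c(F)c(Oc2cccc(N)c2)nc(Oc2cccc(C(=N)N)c2)c1F`: in an assay on isolated protein for inhibition of serine protease 1 (Bos taurus) (a higher number here means a weaker inhibitor, a lower number a stronger inhibitor), compound 1 gives > 5000 nM, which is a limit of the assay and not a number.
Compound 2, `Cc1c(F)c(Oc2cccc(C(=N)N)c2)nc(Oc2cccc(C(=O)N3CCOCC3)c2)c1F`: in this assay compound 2 gives > 5000 nM, again only a limit.

Both measured compounds therefore sit at the same edge of what this assay can report, as summed up by the limit of > 5000 nM in this assay, at which 2 of the 2 values shown sit. Within the data shown here, the single change between them, a step that the two limits leave unreadable from compound 1 to compound 2, cannot be sized, since two limits say nothing about how far apart the true values lie. Compound 2 thus stands at the limit, with no number of its own.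

Compound 3, `Cc1c(F)c(Oc2cccc(CCC(=O)N(C)C)c2)nc(Oc2cccc(C(=N)N)c2)c1F`, differs from compound 2 in one place: 2-(dimethylcarbamoyl)ethyl in place of (morpholin-4-yl)carbonyl on an aromatic carbon. Among the measured compounds shown here, the only measured step that bears on this position is a step that the two limits leave unreadable from compound 1 to compound 2, and it is unreadable, so it gives no direction and no size to lean on. In this assay compound 3 is therefore expected to land again at or near the limit, with an estimate of 8000 nM and a range of 2500 nM to 30000 nM. The expected step from compound 2 is a step that the limit leaves unreadable from compound 2 to compound 3, with no movement beyond the scatter claimed.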

Compound 3, inhibition constant: 4900 nM
Compound 3: middle estimate off by 1.6-fold (0.21 log units), on the high side; the measured number falls inside the stated range.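

In this assay compound 3 gives 4900 nM, a real number and the first one in this series, so this position on the shared core can now be given a measured reading. The other two compounds remain at the edge of what can be reported, and their values are limits of the assay, not numbers: the limit of > 5000 nM in this assay, at which 2 of the 3 values shown sit. Swapping in the open-chain 2-(dimethylcarbamoyl)ethyl group gives an at least 1.0-fold lower number from compound 2 to compound 3 (0.00 log units; that floor lies within the scatter), and the same group in place of amino gives an at least 1.0-fold lower number from compound 1 to compound 3 (0.00 log units; that floor lies within the scatter); these are only floors, so they show that an arm with no ring can give a readable value, but not that it does better than either group it replaces.

As far as these compounds go, how far the true values of compound 1 and compound 2 lie from that of compound 3 remains open, and so does how much this position matters for this assay. Also open, from the compounds shown here alone, is what a carboxylic acid or an amine at the end of a longer chain would give on the same aromatic carbon.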